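Chloro to methyl on the pyridine: expected lipophilicity

This account rests on a few compounds, and the source may have more. Where it says the series, first, only, none or still open, it means among the compounds named here.

Of the compounds shown here, three with a shared core have been measured in a physicochemical assay for lipophilicity, read by LC-MS, in phosphate buffer, measured as octanol-water partition, with a stated time of 30 min, at pH 7.4, tested at 200 mM; a higher number here means a more lipophilic compound, a lower number a more polar compound. Compound 1 `Cc1ccc(Oc2ccc3nc(COc4cccc(C(=O)O)c4)n(C)c3n2)cc1` gives 1.7. Compound 2 `Cn1c(COc2cccc(C(=O)O)c2)nc2ccc(Oc3ccc4c(c3)OCC4)nc21` gives 1.4, and the change a number 0.30 log units lower from compound 1 to compound 2 (within the scatter). Compound 3 `Cn1c(COc2cccc(C(=O)O)c2)nc2ccc(Oc3cc(Cl)ccn3)cc21` gives 1.2, the lowest of the three numbers: its gap to compound 2 lies within the scatter, while its gap to compound 1 lies beyond it.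

Compound 4 `Cc1ccnc(Oc2ccc3nc(COc4cccc(C(=O)O)c4)n(C)c3c2)c1` differs from compound 3 in one place: methyl in place of chloro on an aromatic carbon. Going by the values given here, none of the measured steps makes this exchange, so the step from compound 1 to compound 2, which swaps one aryl group for another on the ether oxygen, bears on it only as a reminder that single changes on this core have so far stayed small. Compound 4 is therefore expected to sit close to compound 3, with a step of a number 0.10 log units lower from compound 3 to compound 4 (within the scatter) that would not clearly exceed the scatter. The estimate for compound 4 in this assay is 1.1, between 0.7 and 1.5.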

Compound 4, distribution coefficient: 0.8
Compound 4: middle estimate off by 0.30 log units, on the high side, and the stated range covers the measured number.
By their numbers in this assay, from the lowest: compound 4; then compounds 3, 2 and 1 (each within the scatter of the next, the first and the last beyond it).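

Going from 4-chloropyridin-2-yl to 4-methylpyridin-2-yl on the aromatic carbon opposite the ring nitrogen gives, in this assay, a number 0.40 log units lower from compound 3 to compound 4 (beyond the scatter). The only earlier step on the shared core, a number 0.30 log units lower from compound 1 to compound 2 (within the scatter), replaced a whole aryl group on the ether oxygen, so this is the first step shown to pass the scatter, and it comes from exchanging one heavy atom for one heavy atom, with no change in the counted hydrogen-bond donors or acceptors. Nothing measured here accounts for the size or direction of this step.

On these data alone, it remains open whether methyl in place of chloro would give a similar step at another place on this ring. Nor do the compounds shown tell how a methoxy group, an amine or a bare hydrogen on the same carbon would read in this assay.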